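Swapping the Aryl Group on the Ring Amine

This account rests on a few compounds, and the source may have more. Where it says the series, first, only, none or still open, it means among the compounds named here.

Compound 1, `Nc1scc(CN2CCN(c3ccccc3C(F)(F)F)CC2)c1C(=O)c1ccc(Cl)cc1`, was tested in a functional assay on CHO cells with adenosine receptor A1 (Homo sapiens) as the target, read by cAMP accumulation and immunoassay, with a stated time of 6 min, tested at 10 uM (a higher number here means a weaker effect of the compound at the concentration tested, a lower number a stronger effect), and gives -60%. Among the measured compounds shown here, its only measured companion is compound 2, `Nc1scc(CN2CCC(c3ccc(Cl)cc3)CC2)c1C(=O)c1ccc(Cl)cc1`; in this assay compound 2 gives -61%. The two readings lie within the usual scatter of each other, so compound 1 stands highest of the two numbers only in the barest sense and neither compound can be told apart from the other.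

Compound 3, `Nc1scc(CN2CCN(c3ccc(F)cc3F)CC2)c1C(=O)c1ccc(Cl)cc1`, has not yet been measured. It differs from compound 1 in one place: 2,4-difluorophenyl in place of 2-(trifluoromethyl)phenyl on an amine nitrogen in a ring. Because compound 2 gives -61% and compound 1 gives -60% despite carrying different groups in this region, the step from compound 1 to compound 3 is expected to stay within the scatter in this assay, with no clear direction. Compound 3 is expected to give -57% in this assay, within a range from -80% to -30%, corresponding to an expected step of a number 3 percentage points higher from compound 1 to compound 3 (within the scatter).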

Compound 3, a percentage reported as activity, at one concentration (the size of the read-out at that concentration, not a potency): -82%
Compound 3: middle estimate off by 25 percentage points, on the high side; measured number below the stated range.
By their numbers in this assay, from the lowest: compound 3; then compounds 2 and 1 (each within the scatter of the next).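

This result shows that the aryl group on the ring amine is a position where the reading can move: in this assay, placing 2,4-difluorophenyl where 2-(trifluoromethyl)phenyl stood gives a number 22 percentage points lower from compound 1 to compound 3 (beyond the scatter), which points to a stronger effect at the concentration tested. The earlier pair could not show this, since its two readings lay within the scatter of each other and its members differ in more than one place. Nothing available explains why this swap shifts the reading.

Going by these compounds, what remains open is which part of the change matters, since one aryl group replaces another that carries different substituents. Plain phenyl or 4-fluorophenyl on the same amine nitrogen would help to separate the contribution of each fluorine from the loss of trifluoromethyl.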